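Diethylamino for amino on a permeability-tested amine series

A few compounds are considered here, and "the series" means these few. Any claim that something is new, unique, unknown or untested is made for them only; others in the source may bear on it.

Measured compounds:
- compound 1, `NCCCCN(C[C@H]1Cc2ncccc2CN1)[C@H]1CCCc2cccnc21`, 17 nm/s
- compound 2, `CN(C[C@H]1Cc2ncccc2CN1)[C@H]1CCCc2cccnc21`, 460 nm/s
- compound 3, `NC(=O)NC/C=C/CN(C[C@H]1Cc2ncccc2CN1)[C@H]1CCCc2cccnc21`, 6 nm/s

These three compounds share one core and differ only in what sits on the chain carbon bound to the amine nitrogen. In an ADME assay for permeability, using PAMPA, with a stated time of 4 h, at pH 5.5 (on this read-out lower numbers stand for lower permeability and higher numbers for higher permeability), compound 1 stands second highest of the three: compound 3 is nearest to it, and compound 2 is furthest. The step of a 27-fold higher number from compound 1 to compound 2 (1.43 log units; beyond the scatter) is the large one, while a 2.8-fold lower number from compound 1 to compound 3 (0.45 log units; beyond the scatter) is modest and a 77-fold lower number from compound 2 to compound 3 (1.88 log units; beyond the scatter) is large.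

Compound 4, `CCN(CC)CCCCN(C[C@H]1Cc2ncccc2CN1)[C@H]1CCCc2cccnc21`, keeps the chain of compound 1 but changes its end: diethylamino in place of amino on a saturated chain carbon, four bonds along the chain from an amine nitrogen. Going by the values given here, no measured step changes the end of this chain while keeping it, so the expectation rests on the steps around it. The step of a 27-fold higher number from compound 1 to compound 2 (1.43 log units; beyond the scatter) shows that taking the whole chain away raises the number greatly, and a 77-fold lower number from compound 2 to compound 3 (1.88 log units; beyond the scatter) shows that a longer chain with more nitrogen and oxygen lowers it greatly. Compound 4 keeps a chain, so the expected rise from compound 1 is smaller than the rise to compound 2; the expected step is a 3.5-fold higher number from compound 1 to compound 4 (0.55 log units; beyond the scatter). The estimate for compound 4 in this assay is 60 nm/s, with a range from 20 nm/s to 200 nm/s.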

Compound 4, apparent permeability: 3 nm/s
Estimate against measurement, compound 4: 20-fold (1.30 log units) above, outside the stated range (below it).
By their numbers in this assay, from the lowest: compounds 4 and 3 (each within the scatter of the next); then compound 1; then compound 2.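

In this assay, going by these compounds alone, the end of the chain proves to matter on its own: with the chain kept, diethylamino in place of amino gives a 5.7-fold lower number from compound 1 to compound 4 (0.75 log units; beyond the scatter) in the first measured change at this chain end. Against hydrogen, the 3-(diethylamino)propyl group gives a 150-fold lower number from compound 2 to compound 4 (2.19 log units; beyond the scatter) as the largest step in the set, while a 2.0-fold lower number from compound 3 to compound 4 (0.30 log units; within the scatter) leaves those two compounds indistinguishable despite their different chains. Nothing among the data shown explains these results.

The compounds shown leave open how a chain ending in dimethylamino or piperidine would read here, and whether a carboxylic acid at that end would move the number the same way. They also leave open whether diethylamino on a shorter chain would give a number closer to that of compound 2.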